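Tolerance series: acetamido to amino on the shared core

A few compounds are considered here, and "the series" means these few. Any claim that something is new, unique, unknown or untested is made for them only; others in the source may bear on it.

Going by the values given here, compound 1 `CNc1ccc(Sc2ccc([N+](=O)[O-])cc2)c(C(=O)Nc2ccccc2OC)c1` and compound 2 `COc1ccccc1NC(=O)c1cc(NC(C)=O)ccc1Sc1ccc([N+](=O)[O-])cc1` are the two members measured so far. In an ADME assay on H9 cells (Homo sapiens) for cytotoxicity, read by MTT assay, with a stated time of 7 days (a lower number here means that less compound is tolerated, a higher number that more compound is tolerated), compound 1 gives 302000 nM. In this assay compound 2 gives 171000 nM, the lower of the two numbers; its nearest neighbour is compound 1, and the gap between them is within the scatter, so the two are not separated by this measurement.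

Compound 3 `COc1ccccc1NC(=O)c1cc(N)ccc1Sc1ccc([N+](=O)[O-])cc1` has not yet been measured. It differs from compound 2 in one place: hydrogen in place of acetyl on a nitrogen on an aromatic ring.

Among the compounds with values here, only one measured step touches the same nitrogen, the exchange of the group on it: a 1.8-fold lower number from compound 1 to compound 2 (0.25 log units; within the scatter). Within the data shown here, no other measured step bears on the change. Among the measured compounds shown here, with the single relevant step flat, the expectation for this assay is a step of a 1.2-fold higher number from compound 2 to compound 3 (0.07 log units; within the scatter), that is, no movement beyond the scatter in either direction. Compound 3 is therefore estimated at 200000 nM, with a likely range from 90000 nM to 450000 nM.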

Compound 3, half-maximal cytotoxic concentration: 506000 nM
Estimate against measurement, compound 3: 2.5-fold (0.40 log units) below, and the stated range ends below it.
By their numbers in this assay, from the lowest: compounds 2, 1 and 3 (each within the scatter of the next, the first and the last beyond it).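

Working notes on the nitrogen on the aromatic ring: in this assay the acetamido to amino change gives a 3.0-fold higher number from compound 2 to compound 3 (0.47 log units; beyond the scatter) and is the first one-place step in the series to clear the scatter, so the group on this nitrogen can shift the tolerated concentration, if only modestly. The same position does not respond to every exchange, since hydrogen in place of methyl gives a 1.7-fold higher number from compound 1 to compound 3 (0.22 log units; within the scatter) and leaves the two compounds unseparated; within this set only the exchange between acetyl and hydrogen resolves, and the series therefore shows one separated pair rather than a graded trend across the three compounds. Nothing available accounts for the step between acetyl and hydrogen, so it stands as an observation without an explanation.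

The compounds shown leave open whether a longer acyl chain such as propionyl, or a dimethylamino group, on this nitrogen would fall with acetyl or with hydrogen. They also leave open whether the step holds when the nitrogen carries a sulfonamide, or when the nitro group elsewhere on the shared core gives way to a nitrile.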